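Methylation of a Resorcinol-Type Hydroxyl in Stilbene Analogues

The source may hold more compounds than are shown below. What is called first, only, known or untested is meant among the compounds shown, and "the series" means these compounds.

The measured compounds are:

Compound 1, `CC(C)(C)c1cc(/C=C/c2cc(O)cc(O)c2)cc(C(C)(C)C)c1O`, 45 nM
Compound 2, `CC(C)(C)c1cc(/C=C/C=C/c2cc(O)cc(O)c2)cc(C(C)(C)C)c1O`, 119 nM
Compound 3, `COc1c(C(C)(C)C)cc(/C=C/C=C/c2cc(O)cc(O)c2)cc1C(C)(C)C`, 410 nM

All three were tested in a functional assay on HT-22 cells (Mus musculus), read by MTT assay, with a stated time of 24 h; a higher number here means that more compound is needed for the effect, a lower number that less compound is needed. Compound 1 gives the lowest of the three numbers, with 45 nM. Compound 2 has 119 nM, and compound 3 has 410 nM. Compound 1 and compound 2 differ in more than one place, and the difference between their cores is not broken down here.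

Compound 2 and compound 3 differ by one change, (methyl in place of hydrogen on an oxygen on an aromatic ring), which gave a 3.4-fold higher number from compound 2 to compound 3 (0.54 log units; beyond the scatter).

The unmeasured compound 4, `COc1cc(O)cc(/C=C/c2cc(C(C)(C)C)c(O)c(C(C)(C)C)c2)c1`, stands to compound 1 exactly as compound 3 stands to compound 2: the difference is methyl in place of hydrogen on an oxygen on an aromatic ring. The place of the change is described in the same words in both pairs, so this is the same change made on a different core. Among the compounds shown it occurs only in these pairs, and only one of them has been measured.

Resting on the single measured instance of the change, compound 4 is expected to need more compound than compound 1, by a step of about a 3.3-fold higher number from compound 1 to compound 4 (0.52 log units; beyond the scatter) in this assay, because the one measured case gave a 3.4-fold higher number from compound 2 to compound 3 (0.54 log units; beyond the scatter). Compound 4 is therefore estimated at 150 nM, with a likely range from 70 nM to 350 nM, the breadth reflecting that the expectation rests on one step on a different core.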

Compound 4, half-maximal effective concentration: 258 nM
Estimate against measurement, compound 4: 1.7-fold (0.24 log units) below, and the stated range covers the measured number.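

On the core of compound 1, going from hydroxy to methoxy gave a 5.7-fold higher number from compound 1 to compound 4 (0.76 log units; beyond the scatter) in this assay, so the number rises here as it does on the core of compound 2. The two cores therefore agree in direction, and the sizes of the two steps cannot be told apart: the same change on two cores in this assay, a 3.4-fold higher number (0.54 log units; beyond the scatter) from compound 2 to compound 3 and a 5.7-fold higher number (0.76 log units; beyond the scatter) from compound 1 to compound 4, 1.7-fold (0.22 log units) apart, within the scatter of two such steps. This supports carrying the change between these two cores as a rise of similar size, but it rests on only two pairs, and it does not show that the change would behave alike on any other core, nor does it explain why the number rises; moreover, the printed description of the place does not separate the hydroxy groups of these compounds, and the two pairs do not methylate the same one.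

The compounds shown leave open whether each hydroxy group on a single core responds in the same way, and what happens when every hydroxy group on a core carries a methyl. They also leave open whether a longer chain such as ethyl on that oxygen, or an amine in place of the hydroxy group, would move the number in the same direction as methyl does.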